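Adding a hydroxy group to compound 1

The source may hold more compounds than are shown below. What is called first, only, known or untested is meant among the compounds shown, and "the series" means these compounds.

Measured so far in a functional assay, read by spectrophotometry, with a stated time of 20 min; on this read-out higher numbers stand for weaker inhibition and lower numbers for stronger inhibition
- compound 1 `Cc1c(-c2ccccc2)oc2ccccc2c1=O` gives 106 ug/mL
- compound 2 `COc1cccc(-c2oc3ccccc3c(=O)c2C)c1` gives 156 ug/mL

Going by the values given here, compound 1 stands level with compound 2, the only other measured compound, as their two numbers lie within the scatter of each other. Compound 3 `Cc1c(-c2ccccc2O)oc2ccccc2c1=O` is still unmeasured. It carries hydroxy in place of hydrogen on an aromatic carbon, ortho to a large group (hydroxy in place of hydrogen on an aromatic carbon). Among the compounds with values here, one measured step bears on this change, methoxy in place of hydrogen on an aromatic carbon, and it is small (a 1.5-fold higher number from compound 1 to compound 2 (0.17 log units; within the scatter)). Within the data shown here, that step involves a different group, and no hydroxy compound has a measured value yet, so it is only a loose guide. On that evidence, no step beyond the scatter is expected in this assay in either direction. The estimated step is small (a 1.1-fold lower number from compound 1 to compound 3 (0.03 log units; within the scatter)). For compound 3 the estimated value is 100 ug/mL with an expected range from 40 ug/mL to 220 ug/mL for now.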

Compound 3, half-maximal inhibitory concentration: 79.4 ug/mL
Compound 3: the middle estimate sits 1.3-fold (0.10 log units) above what was measured; low and high end bracket the measured number.
By their numbers in this assay, from the lowest: compounds 3, 1 and 2 (each within the scatter of the next).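

In this assay, hydroxy on an aromatic carbon, ortho to a large group, gives a 1.3-fold lower number from compound 1 to compound 3 (0.13 log units; within the scatter). The earlier compounds shown here held no hydroxy group, so this is new information: at this place, a group counted as one hydrogen-bond donor and one hydrogen-bond acceptor leaves the number within the scatter of compound 1. Nothing measured here explains how hydroxy acts at this place.

From the compounds shown here alone, whether an amine or a carboxylic acid on this same carbon would move the number beyond the scatter remains open. It is also open whether hydroxy would stay within the scatter on the other carbons of this ring, since the compounds shown place it on only one of them.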